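Amide aryl replacement at the carbonyl of the shared core

A few compounds are considered here, and "the series" means these few. Any claim that something is new, unique, unknown or untested is made for them only; others in the source may bear on it.

Among the measured compounds shown here, compound 2 `O=C(NCc1cccc(Cn2cnc3ccccc32)c1)c1cc2ccccc2[nH]1` gives 9.3 nM in an assay on P815 cells for inhibition of Indoleamine 2,3-dioxygenase 1 (Mus musculus), read by HPLC, with a stated time of 16 h (on this read-out lower numbers stand for stronger inhibition and higher numbers for weaker inhibition), the lowest of the two numbers so far. Its nearest neighbour, compound 1 `O=C(NCc1cccc(Cn2cnc3ccccc32)c1)c1cc(Br)c[nH]1`, gives 12.7 nM in this assay; the exchange of 4-bromo-1H-pyrrol-2-yl for 1H-indol-2-yl on the carbonyl carbon produced a 1.4-fold lower number from compound 1 to compound 2 (0.14 log units; within the scatter). Compound 3 `N#Cc1ccc(C(=O)NCc2cccc(Cn3cnc4ccccc43)c2)cc1` is not yet measured in this assay. It differs from compound 2 as follows: 4-cyanophenyl in place of 1H-indol-2-yl on a carbonyl carbon. For the measured compounds named here, the only measured step at this carbonyl carbon, a 1.4-fold lower number from compound 1 to compound 2 (0.14 log units; within the scatter), swapped one five-membered aromatic ring with a hydrogen-bond donor for another and stayed within the scatter, so it says little about moving to 4-cyanophenyl, which carries no hydrogen-bond donor. The data support no step beyond the scatter, though the missing donor leaves room for a higher number. Compound 3 is expected to give 25 nM in this assay, within 8 nM to 80 nM, an estimated 2.7-fold higher number from compound 2 to compound 3 (0.43 log units; beyond the scatter).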

Compound 3, half-maximal inhibitory concentration: 112 nM
Compound 3: middle estimate off by 4.5-fold (0.65 log units), on the low side, outside the stated range (above it).
By their numbers in this assay, from the lowest: compounds 2 and 1 (each within the scatter of the next); then compound 3.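

At the carbonyl carbon the aryl group is not interchangeable: in this assay the exchange for 4-cyanophenyl gives a 12-fold higher number from compound 2 to compound 3 (1.08 log units; beyond the scatter) and, from the other ring, an 8.8-fold higher number from compound 1 to compound 3 (0.95 log units; beyond the scatter), whereas 1H-indol-2-yl and 4-bromo-1H-pyrrol-2-yl lie within the scatter of each other. Both steps combine several changes at once, since the five-membered aromatic ring and its hydrogen-bond donor leave while a nitrile enters, so the loss in these steps cannot be assigned to any one of them. No supporting measurement bears on why this change raises the number.

The compounds shown leave open whether plain phenyl on the carbonyl carbon would behave like 4-cyanophenyl. They also leave open whether 4-aminophenyl or 4-hydroxyphenyl, each a six-membered ring carrying a hydrogen-bond donor, would return to the values of the two donor-bearing rings.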